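The source may hold more compounds than are shown below. What is called first, only, known or untested is meant among the compounds shown, and "the series" means these compounds.

Compound 2 `N#Cc1c(-c2cccs2)nc2c(c(-c3ccccc3)nn2-c2ccccc2)c1-c1ccc(O)cc1` gives 34200 nM in a functional assay on MV4-11 cells (Homo sapiens) for antiproliferative activity, read by resazurin assay, with a stated time of 72 h (a lower number here means a stronger inhibitor, a higher number a weaker inhibitor), the highest of the two numbers at hand; compound 1 `COc1ccc(-c2nc3c(c(-c4ccccc4)nn3-c3ccccc3)c(-c3ccc(O)cc3)c2C#N)cc1` gives 1600 nM in this assay. Compound 3 `N#Cc1c(-c2ccccc2)nc2c(c(-c3ccccc3)nn2-c2ccccc2)c1-c1ccc(O)cc1` differs from compound 2 by phenyl in place of thiophen-2-yl on an aromatic carbon. Among the compounds with values here, the only step that bears on this is a 21-fold higher number from compound 1 to compound 2 (1.33 log units; beyond the scatter), where thiophen-2-yl took over from 4-methoxyphenyl. Reversing away from thiophen-2-yl toward phenyl, a plain six-membered ring without the methoxy group, is therefore expected to lower the number, though perhaps not fully back, giving a 6.8-fold lower number from compound 2 to compound 3 (0.84 log units; beyond the scatter). Compound 3 is estimated at 5000 nM, within 1500 nM to 16000 nM.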

Compound 3, half-maximal inhibitory concentration: 26100 nM
Estimate against measurement, compound 3: 5.2-fold (0.72 log units) below; the whole stated range lies below it.
By their numbers in this assay, from the lowest: compound 1; then compounds 3 and 2 (each within the scatter of the next).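

With a 1.3-fold lower number from compound 2 to compound 3 (0.12 log units; within the scatter) in this assay, thiophen-2-yl and phenyl at this position cannot be told apart, so a six-membered ring alone does not restore the activity of compound 1. The step of a 16-fold higher number from compound 1 to compound 3 (1.21 log units; beyond the scatter) isolates the methoxy group on that phenyl ring, and this single change accounts for a large difference in the number. No measurement shown explains this link between the methoxy group and activity. Still open, from the compounds shown here alone, is whether an ethoxy group or an amine in place of methoxy would keep the lower number.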